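This account rests on a few compounds, and the source may have more. Where it says the series, first, only, none or still open, it means among the compounds named here.

Compound 1 `CCCCCCCCn1cc(/C=C/C(=O)c2ccc(NC(=O)CN3CCN(c4ccccc4F)CC3)cc2)nn1` was examined in a functional assay on SK-N-SH cells (Homo sapiens) for inhibition, read by MTT assay; on this read-out lower numbers stand for stronger inhibition and higher numbers for weaker inhibition. In that setting compound 1 gives 60300 nM, which is the highest of the two numbers recorded so far. Among the measured compounds shown here, the only other measured compound is compound 2 `CCCCCCCCn1cc(/C=C/C(=O)c2ccc(NC(=O)CBr)cc2)nn1`, which differs from compound 1 in the group attached to the amide; in this assay compound 2 gives 8460 nM, a lower number than that of compound 1 and separated from it by more than the usual scatter. For the measured compounds named here, no single-point step between these two has been worked out, so nothing more is taken from that pair.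

Compound 3 `CCCCCCCCn1cc(/C=C/C(=O)c2ccc(NC(=O)CN3CCN(c4ccccc4OC)CC3)cc2)nn1` has not yet been measured. It differs from compound 1 in one place: methoxy in place of fluoro on an aromatic carbon. The exchange puts methoxy in place of fluoro on an aromatic carbon of a six-membered aromatic ring of carbon only, ortho to a large group. Going by the values given here, no measured pair isolates such an exchange, so the expectation rests on compound 1 alone. The expected step is a 1.1-fold lower number from compound 1 to compound 3 (0.04 log units; within the scatter), that is, no change beyond the scatter in either direction. Compound 3 is therefore expected to give about 55000 nM in this assay, within a range from 20000 nM to 150000 nM.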

Compound 3, half-maximal inhibitory concentration: 21500 nM
Estimate against measurement, compound 3: 2.6-fold (0.41 log units) above; measured number inside the range.
By their numbers in this assay, from the lowest: compound 2; then compound 3; then compound 1.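

Exchanging 2-fluorophenyl for 2-methoxyphenyl gives, in this assay, a 2.8-fold lower number from compound 1 to compound 3 (0.45 log units; beyond the scatter), so this aromatic carbon, ortho to a large group, is not indifferent to the group it carries. This is the first step in the series that can be read at a single place, and although it is modest, it lies beyond the scatter, which compound 1 alone could not have shown. Nothing at hand accounts for the step, which therefore stands as an observation without an explanation.

The compounds shown leave open whether the step comes from the oxygen of the methoxy group or simply from the larger group, a question that a methyl, hydroxy or chloro group on the same aromatic carbon would bear on. They also leave open how a phenyl ring with no group at this place would compare, and whether the same exchange would give a step of similar size elsewhere on the ring or with a shorter chain in place of the octyl chain of compound 1 and compound 3.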